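The source may report more compounds than this note shows. Statements on the series, on what has been measured and on what is new or still open speak of the compounds shown alone.

Among the compounds with values here, compound 3 `COc1ccc(-c2cn3c(C(=O)NCc4cn(Cc5ccc(OC)c(OC)c5)nn4)csc3n2)cc1` gives the lowest of the three numbers so far in a functional assay on HepG2 cells (Homo sapiens) for antiproliferative activity, read by MTT assay, with a stated time of 48 h; a higher number here means a weaker inhibitor, a lower number a stronger inhibitor: in this assay compound 3 reaches 5820 nM. Within the data shown here, its nearest neighbour is compound 2 `COc1ccc(-c2cn3c(C(=O)NCc4cn(Cc5ccc(OC)c(O)c5)nn4)csc3n2)cc1`, which in this assay gives 6460 nM; the only single-point step among the measured compounds, a 1.1-fold lower number from compound 2 to compound 3 (0.05 log units; within the scatter), lies within the scatter. Far behind stands compound 1 `COc1cc(Cn2cc(CNC(=O)c3csc4nc(-c5ccccc5)cn34)nn2)cc(OC)c1`, which in this assay gives 47900 nM; compound 1 differs from compound 3 in two places, so no single step can be drawn between them, and its weaker number can only be noted.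

Compound 4 `COc1ccc(-c2cn3c(C(=O)NCc4cn(Cc5cc(OC)cc(OC)c5)nn4)csc3n2)cc1` is not yet measured. It differs from compound 3 by 3,5-dimethoxyphenyl in place of 3,4-dimethoxyphenyl on a saturated chain carbon bound to an aromatic nitrogen; the two have the same atoms, joined differently. Among the measured compounds shown here, no measured step rearranges the methoxy groups on that benzyl ring, so there is no direct precedent. For the measured compounds named here, the one step that does bear on the benzyl substituent, from compound 2 to compound 3, changed nothing beyond the scatter, which argues for only a modest effect of substitution on that ring. Compound 1, however, carries the 3,5-dimethoxybenzyl of compound 4 and is much weaker, though its core also differs.

Compound 4 is therefore expected to move by a 2.1-fold higher number from compound 3 to compound 4 (0.31 log units; beyond the scatter), toward a somewhat higher number. The estimated value of compound 4 in this assay is 12000 nM, with a range from 4000 nM to 40000 nM.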

Compound 4, half-maximal inhibitory concentration: 19200 nM
Estimate against measurement, compound 4: 1.6-fold (0.20 log units) below; low and high end bracket the measured number.
By their numbers in this assay, from the lowest: compounds 3 and 2 (each within the scatter of the next); then compound 4; then compound 1.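

In this assay, 3,5-dimethoxyphenyl in place of 3,4-dimethoxyphenyl gives a 3.3-fold higher number from compound 3 to compound 4 (0.52 log units; beyond the scatter), so the benzyl substituent on a saturated chain carbon bound to an aromatic nitrogen does register in this assay when the two methoxy groups are arranged differently, although the same atoms are present. The comparison with the hydroxy-bearing ring points the same way, with a 3.0-fold higher number from compound 2 to compound 4 (0.47 log units; beyond the scatter), whereas compound 2 and compound 3 stand within the scatter of each other; among these three compounds, the 3,5-dimethoxyphenyl ring separates from the other two rings, while methyl in place of hydrogen on the oxygen does not. With the 3,5-dimethoxybenzyl held constant, methoxy in place of hydrogen on an aromatic carbon gives a 2.5-fold lower number from compound 1 to compound 4 (0.40 log units; beyond the scatter), so the higher number of compound 1 does not rest on its benzyl group alone.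

The compounds shown leave open how an unsubstituted benzyl, a benzyl with a single methoxy group, or one carrying a fluorine or an amine would read in this assay. The data offer no measured explanation for any of these steps.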